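This account rests on a few compounds, and the source may have more. Where it says the series, first, only, none or still open, it means among the compounds named here.

Of the compounds shown here, two have been measured in a functional assay on NCI-H226 cells (Homo sapiens) for inhibition; on this read-out lower numbers stand for stronger inhibition of growth and higher numbers for weaker inhibition of growth. Within the data shown here, compound 1, `CC(=O)CC/C=C(\C)CCC1=C(C)CCCC1(C)C`, is the first of them. In this assay compound 1 gives > 15000 nM, which is a limit of the assay rather than a number, (the limit of > 15000 nM in this assay, at which 1 of the 2 values shown sits). Compound 2, `C=C1CCC[C@H]2[C@](C)(CC[C@]3(C)CC[C@@H]([C@@H](C)C(=O)O)OO3)[C@@H](C)CC[C@]12C`, is the second. In this assay compound 2 gives > 5000 nM, again only a limit of the assay and not a number, (the limit of > 5000 nM in this assay, at which 1 of the 2 values shown sits). So compound 2 stands at a limit, and the one other value shown is also a limit; neither tells how weak the inhibition of growth truly is. Compound 3, `C=C1CCC[C@H]2[C@](C)(CC[C@]3(C)CC[C@H]([C@@H](C)C(=O)O)OO3)[C@@H](C)CC[C@]12C`, has not yet been measured. It differs from compound 2 only in configuration: the two compounds have the same atoms and bonds and differ only in configuration as drawn: 1 of 7 stereo elements differ; a stereocentre at a saturated ring carbon is drawn S in compound 2 and R in compound 3. Among the measured compounds shown here, no step between measured compounds is known, so nothing shows how much a change of this kind moves the read-out. With compound 2 sitting at a limit, the expected step that the limit leaves unreadable from compound 2 to compound 3 is one of no size beyond the scatter, with a real chance that compound 3 also returns only a limit. Compound 3 is therefore expected to give about 8000 nM, in a range from 2000 nM to 30000 nM.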

Compound 3, concentration for 50% growth inhibition: 110 nM
Compound 3: middle estimate off by 73-fold (1.86 log units), on the high side; measured number below the stated range.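

Turning a single stereocentre at a saturated ring carbon from S to R gives, in this assay, an at least 45-fold lower number from compound 2 to compound 3 (1.65 log units; beyond the scatter), so this one centre separates a compound that reaches no measurable growth inhibition in the range tested from one that has a real number. Compound 2 gives > 5000 nM, which is a limit of the assay and not a number, so the true size of the step could be larger than the printed figure. The step can be put down to the arrangement in space at this one carbon alone, because nothing else in the structure changes: the fact that compounds 2 and 3 differ only in the configuration as drawn.

As far as these compounds go, it remains open whether the growth inhibition seen with the R arrangement also depends on the carboxylic acid, which an amide or a methyl ester in the same place would test. The compounds shown also say nothing about how much the other six stereo elements matter, so this sensitivity to configuration is known for one centre only.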